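This account rests on a few compounds, and the source may have more. Where it says the series, first, only, none or still open, it means among the compounds named here.

In a functional assay (trachea) with Cavia porcellus as the target (a lower number here means a stronger inhibitor, a higher number a weaker inhibitor), three compounds that share one core differ only in the group on a saturated chain carbon bound to an aromatic nitrogen. Compound 1 `CCCn1nc(-c2cccnc2)c2ccccc2c1=O` gives 3160 nM, compound 2 `O=c1c2ccccc2c(-c2cccnc2)nn1CC1CCCCC1` gives 209 nM and compound 3 `O=c1c2ccccc2c(-c2cccnc2)nn1Cc1cccc(Cl)c1` gives 4170 nM. Compound 3 stands with compound 1 and far from compound 2: the data show a 1.3-fold higher number from compound 1 to compound 3 (0.12 log units; within the scatter), whereas they also show a 20-fold higher number from compound 2 to compound 3 (1.30 log units; beyond the scatter). The next structure, compound 4 `O=c1c2ccccc2c(-c2cccnc2)nn1CCSc1ncccn1`, carries a further change at the same place: ((pyrimidin-2-yl)sulfanyl)methyl in place of 3-chlorophenyl on a saturated chain carbon bound to an aromatic nitrogen. Here ((pyrimidin-2-yl)sulfanyl)methyl comes in place of 3-chlorophenyl, so an aromatic ring is present on both sides of the change, though of a different kind. Among the compounds with values here, two measured steps bear on this. The swap to 3-chlorophenyl left the number within the scatter, as a 1.3-fold higher number from compound 1 to compound 3 (0.12 log units; within the scatter) shows, while the only large gain came with cyclohexyl, in a 15-fold lower number from compound 1 to compound 2 (1.18 log units; beyond the scatter). Within the data shown here, the entering group has no cyclohexyl, and no measured compound carries anything like it, so the guide is weak. No step beyond the scatter is therefore expected, and the expected change is a 1.7-fold lower number from compound 3 to compound 4 (0.22 log units; within the scatter). For compound 4 the estimated value is 2500 nM, with an expected range from 500 nM to 10000 nM.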

Compound 4, half-maximal inhibitory concentration: 11000 nM
The estimate for compound 4 lay 4.4-fold (0.64 log units) below the measured number; the measured number lies above the stated range.
By their numbers in this assay, from the lowest: compound 2; then compounds 1 and 3 (each within the scatter of the next); then compound 4.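

In this assay, within the data shown here, the new value is the first in the set to lie beyond the scatter on the weak side of the earlier compounds that carry no cyclohexyl (a 2.6-fold higher number from compound 3 to compound 4 (0.42 log units; beyond the scatter) and a 3.5-fold higher number from compound 1 to compound 4 (0.54 log units; beyond the scatter)), so this position can lose activity as well as gain it. The step from the 3-chlorophenyl group also shows that the kind of aromatic ring and its link to the chain are not neutral, even though each group holds one six-membered aromatic ring, and the range at this place now runs wider than before, with cyclohexyl still far ahead (a 53-fold higher number from compound 2 to compound 4 (1.72 log units; beyond the scatter)). Nothing available explains why this group gives the weakest number of the four.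

The change swaps the ring and adds a sulfur and a chain atom all at once, so the compounds shown leave open which of these goes with the shift. They also leave open whether the advantage of compound 2 extends to other saturated rings, such as a cyclopentyl or a piperidine, or to a phenylsulfanyl group at the same place.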